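The source may hold more compounds than are shown below. What is called first, only, known or untested is meant among the compounds shown, and "the series" means these compounds.

Measured in an in vivo ADME assay on the whole organism for pharmacokinetics, with Canis familiaris (Canis lupus familiaris) as the target; a higher number here means that a larger share of the oral dose reaches the circulation, a lower number that a smaller share of the oral dose reaches the circulation:
- compound 1 `Nc1noc2ccc(-n3nc(C(F)(F)F)c4c3C(=O)N(c3ccc(-c5ccccc5CN5CCCC5)cc3F)CC4)cc12`: 85%
- compound 2 `Cc1nn(-c2ccc3onc(N)c3c2)c2c1CCN(c1ccc(-c3ccccc3CN3CCCC3)cc1)C2=O`: 10%

Compound 1 stands higher of the two, beyond the scatter from compound 2. Next comes compound 3 `Nc1noc2ccc(-n3nc(C(F)(F)F)c4c3C(=O)N(c3ccc(-c5ccccc5CN5CCCC5)cc3)CC4)cc12`, which differs from compound 1 in one place: hydrogen in place of fluoro on an aromatic carbon. Going by the values given here, no measured pair shows this change alone, so the expectation is loose. A moderate fall in this assay is expected, though no change beyond the scatter remains possible. The expected move is a number 20 percentage points lower from compound 1 to compound 3 (beyond the scatter). Compound 1, at 85%, leaves more room downward than upward. For compound 3 the estimated value is 65%, expected within 35% to 90%.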

Compound 3, oral bioavailability: 37%
The estimate for compound 3 lay 28 percentage points above the measured number; the range from low to high includes it.
By their numbers in this assay, from the lowest: compound 2; then compound 3; then compound 1.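

In this assay the fluoro ortho to a large group counts for much: hydrogen in its place gives a number 48 percentage points lower from compound 1 to compound 3 (beyond the scatter) in a single change. Trifluoromethyl in place of methyl on an aromatic carbon also shifts the number, with a number 27 percentage points higher from compound 2 to compound 3 (beyond the scatter) as its step. No measurement at hand gives a reason for either step.

Going by these compounds, whether chloro or methoxy at the fluoro position would keep the number near that of compound 1 stays open. So does whether the fluoro step would be of similar size with methyl in place of trifluoromethyl.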